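Adding a chloro group to the aryl urea of compound 3

This account rests on a few compounds, and the source may have more. Where it says the series, first, only, none or still open, it means among the compounds named here.

Measured compounds:
compound 1, `COc1cc(-c2nn(-c3cccc(NC(=O)Nc4cc(C(F)(F)F)cc(C(F)(F)F)c4)c3)cc2-c2ccncc2)ccc1Cl`: 2070 nM
compound 2, `COc1cc(-c2nn(-c3cccc(NC(=O)Nc4ccc(Cl)c(Cl)c4)c3)cc2-c2ccncc2)ccc1Cl`: 2830 nM
compound 3, `COc1cc(-c2nn(-c3cccc(NC(=O)Nc4cccc(C(F)(F)F)c4)c3)cc2-c2ccncc2)ccc1Cl`: 2510 nM

All three share one core and differ only in the aryl group on the urea. In a functional assay on PC-3 cells (Homo sapiens) for inhibition, read by sulforhodamine B assay, with a stated time of 48 h (a higher number here means a weaker inhibitor of growth, a lower number a stronger inhibitor of growth), compound 3 stands second highest of the three numbers, with compound 2 nearest and compound 1 furthest, and both of those gaps lie within the scatter. The step of a 1.2-fold higher number from compound 1 to compound 3 (0.08 log units; within the scatter) and the step of a 1.1-fold lower number from compound 2 to compound 3 (0.05 log units; within the scatter) are each within the scatter, so the three measured aryl groups have not been told apart by this assay.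

Compound 4, `COc1cc(-c2nn(-c3cccc(NC(=O)Nc4ccc(Cl)c(C(F)(F)F)c4)c3)cc2-c2ccncc2)ccc1Cl`, has not yet been measured. It differs from compound 3 by chloro in place of hydrogen on an aromatic carbon; the chloro enters on an aromatic carbon of a six-membered aromatic ring of carbon only, ortho to a trifluoromethyl group and para to a large group. Both known steps bear on it: compound 1 carries a second trifluoromethyl on that ring and compound 2 carries two chloro groups, and neither moved the number beyond the scatter. For compound 4 the expected step is therefore a 1.1-fold lower number from compound 3 to compound 4 (0.04 log units; within the scatter), no change beyond the scatter. Compound 4 is estimated at 2300 nM, within a range of 1100 nM to 4800 nM.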

Compound 4, concentration for total growth inhibition: 2450 nM
The estimate for compound 4 lay 1.1-fold (0.03 log units) below the measured number, and the stated range covers the measured number.
By their numbers in this assay, from the lowest: compounds 1, 4, 3 and 2 (each within the scatter of the next).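

In this assay, among these compounds, chloro in place of hydrogen, on an aromatic carbon ortho to a trifluoromethyl group and para to a large group, gives a 1.0-fold lower number from compound 3 to compound 4 (0.01 log units; within the scatter), so this is the first direct reading of this single change, and compound 3 and compound 4 cannot be told apart. The earlier steps shown here compared other changes on the aryl ring of the urea, whereas the second new step, trifluoromethyl in place of chloro with the 4-chloro group kept in both compounds, gives a 1.2-fold lower number from compound 2 to compound 4 (0.06 log units; within the scatter), so this exchange cannot be read as a difference either. None of the data shown gives a reason for these small steps.

The compounds shown carry only chloro and trifluoromethyl groups on this ring, so it remains open whether an amine or a carboxylic acid on the same carbon would give a step beyond the scatter. On these data alone, it also remains open whether chloro at this position would behave the same way if the urea were replaced by an amide or the 3-chloro-4-methoxy pattern of the shared core were altered.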